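Changing the Ring Nitrogen Substituent of a Peptide Conjugate

The source may report more compounds than this note shows. Statements on the series, on what has been measured and on what is new or still open speak of the compounds shown alone.

Compound 1 `CCCC[C@H](NC(=O)[C@H](CCCCN)NC(=O)[C@H](CCCNC(=N)N)NC(=O)c1ccc(/C=C2\SC(=S)N(c3ccc(Cl)cc3)C2=O)cc1)C(N)=O`: 1.02 10^-6 cm/s
Compound 2 `CCCC[C@H](NC(=O)[C@H](CCCCN)NC(=O)[C@H](CCCNC(=N)N)NC(=O)c1ccc(/C=C2\SC(=O)N(CCCC)C2=O)cc1)C(N)=O`: 1.18 10^-6 cm/s
Compound 3 `CCCC[C@H](NC(=O)[C@H](CCCCN)NC(=O)[C@H](CCCNC(=N)N)NC(=O)c1ccc(/C=C2\SC(=O)N(Cc3ccc(Cl)cc3)C2=O)cc1)C(N)=O`: 1.11 10^-6 cm/s

In an ADME assay for permeability, using PAMPA (a lower number here means that the compound crosses the layer more slowly, a higher number that the compound crosses the layer faster), compound 1 sits at the low end of these three numbers, yet its gaps to compound 3 and to compound 2 are both within the usual scatter, so the three cannot be told apart. Compound 4 `CCCCC(C(=O)OC)N1C(=O)/C(=C/c2ccc(C(=O)N[C@@H](CCCNC(=N)N)C(=O)N[C@@H](CCCCN)C(=O)N[C@@H](CCCC)C(N)=O)cc2)SC1=S` arises from compound 1 by 1-(methoxycarbonyl)pentyl in place of 4-chlorophenyl on an amide-type nitrogen in a ring. Within the data shown here, the only comparison that touches the same position is a 1.1-fold lower number from compound 2 to compound 3 (0.03 log units; within the scatter), a change on the same ring nitrogen that left this assay essentially unmoved. On that basis compound 4 is expected to show a 1.0-fold lower number from compound 1 to compound 4 (0.01 log units; within the scatter), no shift beyond the scatter. The estimated value for compound 4 is 1 10^-6 cm/s, with a range from 0.5 10^-6 cm/s to 2 10^-6 cm/s.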

Compound 4, apparent permeability: 0.87 10^-6 cm/s
The estimate for compound 4 lay 1.1-fold (0.06 log units) above the measured number; measured number inside the range.
By their numbers in this assay, from the lowest: compounds 4, 1, 3 and 2 (each within the scatter of the next).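

In this assay, the step of a 1.2-fold lower number from compound 1 to compound 4 (0.07 log units; within the scatter) comes with the loss of the aromatic ring from this substituent and the arrival of an open chain carrying hydrogen-bond acceptors. The amide-type nitrogen in the ring has therefore now taken an aryl group and a branched ester-bearing chain without any step beyond the scatter. Nothing measured here offers an explanation for this result. As far as these compounds go, whether an amine or a carboxylic acid on this nitrogen would give a step beyond the scatter remains open.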